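The source may hold more compounds than are shown below. What is called first, only, known or untested is meant among the compounds shown, and "the series" means these compounds.

Measured in a functional assay on MIA PaCa-2 cells (Homo sapiens) for antiproliferative activity; a higher number here means that more compound is needed for the effect, a lower number that less compound is needed:

- compound 1 `CC#CC(=O)Nc1cccc2c1cc(C)n2-c1nc2c(c(NCc3ccccc3)n1)CCCC2`: 436 nM
- compound 2 `CCCC#CC(=O)Nc1cccc2c1cc(C)n2-c1nc2c(c(NCc3ccccc3)n1)CCCC2`: 1570 nM

Of these two, compound 2 has the higher number, so more of it is needed for the effect. Compound 3 `C=CC#CC(=O)Nc1cccc2c1cc(C)n2-c1nc2c(c(NCc3ccccc3)n1)CCCC2` differs from compound 2 in one place: vinyl in place of propyl on a triple-bonded carbon.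

Within the data shown here, only one measured step bears on this change, and it concerns the same chain: a 3.6-fold higher number from compound 1 to compound 2 (0.56 log units; beyond the scatter). There, the longer chain went with the higher number. Vinyl is shorter than propyl, so a step of similar size to a lower number is expected, though a double bond is new to this series and the evidence is thin. The estimated change is a 3.1-fold lower number from compound 2 to compound 3 (0.50 log units; beyond the scatter). Compound 3 is estimated at 500 nM, with an expected range from 150 nM to 1500 nM.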

Compound 3, half-maximal effective concentration in the MIA PaCa-2 assay: 892 nM
Compound 3: the middle estimate sits 1.8-fold (0.25 log units) below what was measured; the measured number falls inside the stated range.
By their numbers in the MIA PaCa-2 assay, from the lowest: compound 1; then compounds 3 and 2 (each within the scatter of the next).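

In the MIA PaCa-2 assay, putting vinyl in place of propyl on the triple-bonded carbon does not separate the two compounds: a 1.8-fold lower number from compound 2 to compound 3 (0.25 log units; within the scatter). Methyl at this place still stands apart in the MIA PaCa-2 assay: a 2.0-fold higher number from compound 1 to compound 3 (0.31 log units; beyond the scatter). So among these three compounds the methyl group goes with the lowest number, while the vinyl and propyl compounds cannot be told apart, and in a physicochemical assay for pharmacokinetics, read by LC-MS, in phosphate buffer, tested at 1 uM (on this read-out higher numbers stand for a longer-lived compound and lower numbers for a shorter-lived compound), the same change from propyl to vinyl does leave a clear mark, with compound 3 the shorter-lived: the measured half-life of compound 2, 21.6 h, and of compound 3, 5.08 h, a 4.3-fold lower number (0.63 log units; beyond the scatter)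

In the physicochemical assay compound 2 gives 21.6 h and compound 3 gives 5.08 h as half-life. With only methyl, vinyl and propyl on this carbon, no general rule linking the group to either read-out can be drawn. As far as these compounds go, how an amine or a cyclopropyl group on the triple-bonded carbon would behave in the MIA PaCa-2 assay and the physicochemical assay remains open.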